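Notes on the step from compound 1 to compound 3

The source may hold more compounds than are shown below. What is called first, only, known or untested is meant among the compounds shown, and "the series" means these compounds.

Measured in a functional assay on A549 cells (Homo sapiens) for inhibition, read by sulforhodamine B assay, with a stated time of 48 h (a lower number here means a stronger inhibitor of growth, a higher number a weaker inhibitor of growth), so far
- compound 1 `COc1ccc(/C=C/C(=O)C(=Cc2ccc(N(C)C)cc2)C(=O)/C=C/c2ccc(OC)c(OC)c2)cc1OC` gives 2620 nM
- compound 2 `COc1ccc(C=C(C(=O)/C=C/c2cc(OC)c(OC)c(OC)c2)C(=O)/C=C/c2cc(OC)c(OC)c(OC)c2)cc1OC` gives 370 nM

Compound 1 holds the higher of the two numbers, and compound 2 lies below it, beyond the scatter. The step to compound 3 `COc1ccc(C=C(C(=O)/C=C/c2ccc(OC)c(OC)c2)C(=O)/C=C/c2ccc(OC)c(OC)c2)c(OC)c1` is 2,4-dimethoxyphenyl in place of 4-(dimethylamino)phenyl on a double-bonded chain carbon bound to a double-bonded chain carbon and puts 2,4-dimethoxyphenyl in place of 4-(dimethylamino)phenyl on a double-bonded chain carbon bound to a double-bonded chain carbon. Among the compounds with values here, no measured step isolates this change. Compound 2, at 370 nM without 4-(dimethylamino)phenyl, differs from compound 1 elsewhere too and is only a loose guide. A move to a lower number is expected in this assay with an estimated 2.6-fold lower number from compound 1 to compound 3 (0.42 log units; beyond the scatter) as its size. The estimate for compound 3 is 1000 nM with a range from 300 nM to 3000 nM.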

Compound 3, concentration for 50% growth inhibition: 650 nM
Compound 3: middle estimate off by 1.5-fold (0.19 log units), on the high side; the measured number falls inside the stated range.
By their numbers in this assay, from the lowest: compounds 2 and 3 (each within the scatter of the next); then compound 1.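

In this assay, the change on a double-bonded chain carbon bound to a double-bonded chain carbon gives a 4.0-fold lower number from compound 1 to compound 3 (0.61 log units; beyond the scatter) when 2,4-dimethoxyphenyl replaces 4-(dimethylamino)phenyl. Within the data shown here, this is the first step to isolate that position, and it shows that this exchange alone lowers the number, which the loose comparison of compound 1 with compound 2 could not show. No available evidence bears on the cause of the step.

Going by these compounds, it remains open whether the shift follows from losing dimethylamino or from gaining the methoxy groups. An unsubstituted phenyl at this place would help separate the two.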